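Methoxy in Place of Methyl: Forecasting Compound 4

This account rests on a few compounds, and the source may have more. Where it says the series, first, only, none or still open, it means among the compounds named here.

Compound 1 `COc1cccc(N2C(=O)CS/C2=N\c2csc(-c3ccc(C)cc3)c2)c1` and compound 2 `COc1ccc(-c2cc(/N=C3\SCC(=O)N3c3cccc(OC)c3)cs2)cc1` share a core and differ only by methoxy in place of methyl on an aromatic carbon. In a functional assay on MDA-MB-231 cells (Homo sapiens) for cytotoxicity, read by MTT assay, with a stated time of 72 h (a lower number here means a stronger inhibitor, a higher number a weaker inhibitor), compound 1 gives only a limit, > 50000 nM. Compound 1 thus sits at the limit of > 50000 nM in this assay, at which 1 of the 3 values shown sits. In this assay compound 2 gives 2700 nM. The step between them is an at least 18-fold lower number from compound 1 to compound 2 (1.26 log units; beyond the scatter), and since it starts from a limit, it is known only as a floor.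

Compound 3 `Cc1ccc(/C=C2\S/C(=N\c3nc(-c4ccc(Cl)cc4)cs3)NC2=O)cc1` is built on another core; the difference between the two cores is not broken down here. In this assay compound 3 gives 800 nM, the lowest of the two numbers at hand.

Compound 4 `COc1ccc(/C=C2\S/C(=N\c3nc(-c4ccc(Cl)cc4)cs3)NC2=O)cc1` has not yet been measured. It differs from compound 3 by methoxy in place of methyl on an aromatic carbon, the same change that separates compound 1 from compound 2, at a place described in the same words. The expected step here is a 2.0-fold lower number from compound 3 to compound 4 (0.30 log units; within the scatter), more modest than the earlier one, because the earlier step of an at least 18-fold lower number from compound 1 to compound 2 (1.26 log units; beyond the scatter) is known only as a floor and the cores are not the same. Compound 4 is expected to give 400 nM, with a likely range from 120 nM to 1500 nM.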

Compound 4, half-maximal inhibitory concentration: 300 nM
Beside the measured number, compound 4's estimate is 1.3-fold (0.12 log units) above it, within the range that was stated.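

In this assay, methoxy in place of methyl goes with a lower number on both cores shown, and on the second core the new step is a 2.7-fold lower number from compound 3 to compound 4 (0.43 log units; beyond the scatter), so the direction of the change carries over in these two pairs. Its size does not carry over, and the two steps differ by more than the scatter allows: the same change on two cores in this assay, an at least 18-fold lower number (1.26 log units; beyond the scatter) from compound 1 to compound 2 and a 2.7-fold lower number (0.43 log units; beyond the scatter) from compound 3 to compound 4, at least 6.9-fold (0.84 log units) apart, beyond the scatter of two such steps. As far as these compounds go, compound 1 gives only a limit, so the earlier step is known only as a floor and the true distance between the two steps stays unknown: the limit of > 50000 nM in this assay, at which 1 of the 4 values shown sits.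

Two pairs on two cores also make no rule for any further core in this series, and the direction seen here may not hold there. From the compounds shown here alone, what a hydroxyl, an amine or a carboxylic acid would give in place of the methoxy on this six-membered aromatic ring remains open, on either core.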